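A few compounds are considered here, and "the series" means these few. Any claim that something is new, unique, unknown or untested is made for them only; others in the source may bear on it.

Compound 1 `N#Cc1c(N)cccc1Sc1ccccc1` is the starting point of this small series. In a functional assay on MT4 cells (Homo sapiens) for cytotoxicity (a higher number here means a weaker inhibitor, a lower number a stronger inhibitor), compound 1 gives 168000 nM. Compound 2 `Cc1ccccc1Sc1cccc(N)c1C#N` carries a methyl in place of hydrogen on an aromatic carbon, the change described by methyl in place of hydrogen on an aromatic carbon. For compound 2 the this assay reports only a limit, > 40000 nM, which is the limit of > 40000 nM in this assay, at which 1 of the 3 values shown sits. Because of this limit, the step that the limit leaves unreadable from compound 1 to compound 2 cannot be sized.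

Compound 3 `N#Cc1c(N)cccc1S(=O)(=O)c1cccc(Br)c1` rests on a different core, and the difference between the two cores is not broken down here. For compound 3 the this assay again reports a limit, > 200000 nM, which is the limit of > 200000 nM in this assay, at which 1 of the 3 values shown sits.

Compound 4 `Cc1cc(Br)cc(S(=O)(=O)c2cccc(N)c2C#N)c1` has not yet been measured. It differs from compound 3 by methyl in place of hydrogen on an aromatic carbon. This is the same kind of change as that from compound 1 to compound 2, but not the same: in compound 2 the methyl sits ortho to a large group, while in compound 4 it sits meta to a bromo group and meta to a large group. Since compound 3 shows only a limit, > 200000 nM, the step from compound 1 to compound 2 is unreadable, and the change at the core is not broken down, the expectation for compound 4 is weakly grounded. The step from compound 3 to compound 4 is estimated as a step that the limit leaves unreadable from compound 3 to compound 4. Compound 4 is therefore expected to give about 250000 nM in the this assay, within a range of 120000 nM to 600000 nM, and quite possibly only a limit again.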

Compound 4, half-maximal inhibitory concentration: 133000 nM
For compound 4 the middle estimate is 1.9-fold (0.27 log units) above the measured one; the range from low to high includes it.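

In this assay, among these compounds, methyl in place of hydrogen on an aromatic carbon, here meta to a bromo group and meta to a large group, gives an at least 1.5-fold lower number from compound 3 to compound 4 (0.17 log units; that floor lies within the scatter), which shows only that a readable value for the methyl compound can be set against a limit on this core, not how large the change truly is. That step is no more than a floor, because compound 3 is recorded only as a limit: the limit of > 200000 nM in this assay, at which 1 of the 4 values shown sits. The same kind of change on the core of compound 1 cannot be read, so the series does not show whether the methyl change carries over from one core to the other in size or in direction, because compound 2 is also recorded only as a limit: the limit of > 40000 nM in this assay, at which 1 of the 4 values shown sits.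

The compounds shown leave open how an ethyl group, a methoxy group or a carboxylic acid in place of the same hydrogen would read in this assay. They also leave open how the two cores compare when carrying identical groups, as no pair shown differs at the core alone.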